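Removing the aromatic methyl from compound 1

A few compounds are considered here, and "the series" means these few. Any claim that something is new, unique, unknown or untested is made for them only; others in the source may bear on it.

In a functional assay on cells (Breast carcinoma cell, Homo sapiens) for cytotoxicity, read by sulforhodamine B assay, with a stated time of 48 h (on this read-out lower numbers stand for stronger inhibition of growth and higher numbers for weaker inhibition of growth), compound 1 (`COc1cc2c(cc1C)NC(=O)/C2=C/c1c(OC)nc2sc(C)cn12`) gives 50900 nM as its reading. Compound 2 (`COc1nc2sc(C)cn2c1C=C1C(=O)N(C)c2ccccc21`) gives 58200 nM as its reading. Among the measured compounds shown here, these two values lie within the scatter of each other, so compound 1 stands level with the only other measured compound.

Compound 3 (`COc1ccc2c(c1)/C(=C\c1c(OC)nc3sc(C)cn13)C(=O)N2`) is still unmeasured. It carries hydrogen in place of methyl on an aromatic carbon. For the measured compounds named here, no measured pair isolates this change. Compound 2 also lacks a methyl on its six-membered aromatic ring of carbon only, and its 58200 nM reading stays within the scatter of compound 1, although it differs in other places too. In this assay the expectation is a 1.0-fold lower number from compound 1 to compound 3 (0.01 log units; within the scatter) and so no change beyond the scatter in either direction. Compound 3 is estimated at 50000 nM with an expected range from 22000 nM to 100000 nM in this measurement.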

Compound 3, concentration for total growth inhibition: 61300 nM
Estimate against measurement, compound 3: 1.2-fold (0.09 log units) below, within the range that was stated.
By their numbers in this assay, from the lowest: compounds 1, 2 and 3 (each within the scatter of the next).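

Compound 3 gives the first clean read of this position: in this assay, hydrogen in place of methyl on an aromatic carbon, ortho to a methoxy group, gives a 1.2-fold higher number from compound 1 to compound 3 (0.08 log units; within the scatter) and so leaves the reading level. Compound 2 could only hint at this, as it differs from compound 1 in other places too, whereas this pair isolates the methyl, and on the core of compound 1 the reading holds without it. Nothing available explains why the two readings stay level.

As far as these compounds go, it remains open whether any other group on this aromatic carbon, such as an amine, a carboxylic acid or a longer chain like propyl, would move the reading beyond the scatter. From the compounds shown here alone, it is also open whether hydrogen and methyl stay level here in other cell types.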